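Exchanging 1,3-thiazol-2-yl for 3-methylfuran-2-yl on the core

The source may hold more compounds than are shown below. What is called first, only, known or untested is meant among the compounds shown, and "the series" means these compounds.

Three measured compounds share one core and differ only in the ring group attached to it. Compound 1 `c1cncc(-c2ccccc2OCC2=NCCN2)c1` carries pyridin-3-yl; in a functional assay with Alpha-1A adrenergic receptor (Homo sapiens) as the target, read by calcium flux (a lower number here means a smaller maximal response, a higher number a larger maximal response), compound 1 gives 109%. Compound 2 `c1c[nH]c(-c2ccccc2OCC2=NCCN2)c1` carries 1H-pyrrol-2-yl, and in this assay compound 2 gives 99%. Compound 3 `c1ccc(-c2nccs2)c(OCC2=NCCN2)c1` carries 1,3-thiazol-2-yl, and in this assay compound 3 gives 102%. On the numbers shown, compound 3 is second highest of the three, nearest compound 2 and furthest from compound 1, but both gaps lie within the scatter: a number 3 percentage points higher from compound 2 to compound 3 (within the scatter) and a number 7 percentage points lower from compound 1 to compound 3 (within the scatter). The three compounds therefore cannot be told apart on this read-out.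

Compound 4 `Cc1ccoc1-c1ccccc1OCC1=NCCN1` has not been measured. Its change from compound 3 is 3-methylfuran-2-yl in place of 1,3-thiazol-2-yl on an aromatic carbon. Within the data shown here, no measured step exchanges exactly these two groups. Among the measured compounds shown here, the steps that bear on it are the three exchanges of one ring group for another on the same carbon of the core, a number 10 percentage points lower from compound 1 to compound 2 (within the scatter), a number 7 percentage points lower from compound 1 to compound 3 (within the scatter) and a number 3 percentage points higher from compound 2 to compound 3 (within the scatter), every one within the scatter. A further exchange of this kind is therefore expected to give no step beyond the scatter in this assay, a number 1 percentage points lower from compound 3 to compound 4 (within the scatter). Compound 4 is estimated at 101%, in a range from 86% to 116%.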

Compound 4, largest response reached (reported as maximum), in percent of the reference or control that the assay uses: 99%
Beside the measured number, compound 4's estimate is 2 percentage points above it; the range from low to high includes it.
By their numbers in this assay, from the lowest: compounds 2, 4, 3 and 1 (each within the scatter of the next).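

Putting 3-methylfuran-2-yl on this aromatic carbon brings in a group of 6 heavy atoms with 1 hetero atom in its ring, where 1,3-thiazol-2-yl has 5 heavy atoms and 2 hetero atoms, yet in this assay the result is a number 3 percentage points lower from compound 3 to compound 4 (within the scatter). Among these compounds, this is the first ring group to carry a methyl group, and it also stays within the scatter of the other two ring groups, with no change at the digits printed from compound 2 to compound 4 (within the scatter) and a number 10 percentage points lower from compound 1 to compound 4 (within the scatter), so this position holds four different aromatic rings with no step that can be told from the scatter. No measurement available here speaks to why these exchanges leave the maximal response unresolved.

Every group shown is an aromatic ring, so it remains open whether an amine, a carboxylic acid or a longer alkyl chain on this carbon would give a step beyond the scatter. The read-out also reports only the largest response reached, so it leaves open how the compounds compare in the concentration needed to reach that response.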